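This account rests on a few compounds, and the source may have more. Where it says the series, first, only, none or still open, it means among the compounds named here.

In a functional assay on MCF7 cells (Homo sapiens) for antiproliferative activity, read by MTT assay, with a stated time of 24 h (on this read-out higher numbers stand for weaker inhibition and lower numbers for stronger inhibition), compound 1 `CCCCc1oc2ccccc2c1C(=O)c1ccc(OCC(=O)N2CCN(C(=O)OC(C)(C)C)CC2)cc1` gives 42200 nM and compound 2 `CCCCc1oc2ccccc2c1C(=O)c1ccc(OCC(=O)Nc2ccccc2)cc1` gives 33600 nM, two values within the scatter of each other. Compound 3 `CCCCc1oc2ccccc2c1C(=O)c1ccc(OCCCC(=O)N2CCCC2)cc1` differs from compound 2 by 2-((pyrrolidin-1-yl)carbonyl)ethyl in place of phenylcarbamoyl on a saturated chain carbon bound to an oxygen on an aromatic ring. Within the data shown here, no measured pair differs in one place only, so no direct precedent exists for this change. The two amides measured so far sit at the same level, and no step beyond the scatter is expected in this assay, in either direction. The expected change is a 1.0-fold higher number from compound 2 to compound 3 (0.02 log units; within the scatter). The estimate for compound 3 is 35000 nM, with an expected range of 15000 nM to 80000 nM.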

Compound 3, half-maximal inhibitory concentration: 23500 nM
Compound 3: the middle estimate sits 1.5-fold (0.17 log units) above what was measured; the range from low to high includes it.
By their numbers in this assay, from the lowest: compounds 3, 2 and 1 (each within the scatter of the next).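

Among these compounds, the step of a 1.4-fold lower number from compound 2 to compound 3 (0.16 log units; within the scatter) in this assay is the first one-place comparison at this position. Replacing phenylcarbamoyl with 2-((pyrrolidin-1-yl)carbonyl)ethyl on a saturated chain carbon bound to an oxygen on an aromatic ring exchanges the six-membered aromatic ring for a five-membered non-aromatic ring and drops the hydrogen-bond donor, yet the numbers stay within the scatter. No measurement available here accounts for this result. This single change alters both the amide and the chain, and their separate contributions remain unresolved. As far as these compounds go, whether a carboxylic acid or a primary amine in place of the amide would give a step beyond the scatter also remains open.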